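Lengthening the Ester Chain of a Thiophene-Bearing Urea Core

This account rests on a few compounds, and the source may have more. Where it says the series, first, only, none or still open, it means among the compounds named here.

Compound 3 `CCCOC(=O)C1=C(C)N(C)C(=O)NC1c1cccs1` gives 4% in an assay on membranes from HeLa cells for displacement of a labelled ligand from adenosine receptor A3 (Homo sapiens), read by scintillation counting, with a stated time of 180 min, tested at 1 uM (on this read-out lower numbers stand for less inhibition and higher numbers for more inhibition at the one concentration tested (going by the name of the read-out)), the second highest of three numbers. Its nearest neighbour is compound 2 `CCOC(=O)C1=C(C)N(C)C(=O)NC1c1cccs1`, which gives 2%; the step of a number 2 percentage points higher from compound 2 to compound 3 (within the scatter) is within the scatter. Compound 3 differs in two places from compound 1 `CC1=C(C(=O)OCC(C)C)C(c2ccco2)NC(=O)N1C`, and compound 1 gives 23%, a number beyond the scatter above compound 3. Compound 4 `CC1=C(C(=O)OCC(C)C)C(c2cccs2)NC(=O)N1C` carries the change (methyl in place of hydrogen on a saturated chain carbon bound to two saturated chain carbons). For the measured compounds named here, the only measured step that bears on it, the chain extension from compound 2 to compound 3, was small, so no step beyond the scatter is expected; the estimated step is a number 5 percentage points higher from compound 3 to compound 4 (within the scatter). Compound 4 is therefore expected to give about 9%, between 0% and 24%.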

Compound 4, a percentage reported as inhibition, at one concentration (the size of the read-out at that concentration, not a potency): 5%
Compound 4: middle estimate off by 4 percentage points, on the high side; the range from low to high includes it.
By their numbers in this assay, from the lowest: compounds 2, 3 and 4 (each within the scatter of the next); then compound 1.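

Methyl on a saturated chain carbon bound to two saturated chain carbons gives a number 1 percentage points higher from compound 3 to compound 4 (within the scatter) in this assay and isopropyl in place of methyl on a saturated chain carbon bound to an oxygen next to a carbonyl group gives a number 3 percentage points higher from compound 2 to compound 4 (within the scatter) so neither chain change moves the number beyond the scatter. Thiophen-2-yl in place of furan-2-yl on a saturated ring carbon, with the isobutyl ester unchanged, gives a number 18 percentage points lower from compound 1 to compound 4 (beyond the scatter) and is the only one of these steps beyond the scatter. Nothing available explains this difference.

Open, going by these compounds, is whether a longer chain or a terminal amine on the ester would behave like these chains, and whether furan-2-yl would give a higher number with the ethyl or propyl ester.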